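This account rests on a few compounds, and the source may have more. Where it says the series, first, only, none or still open, it means among the compounds named here.

Compound 1, `N#CCNC(=O)c1ccc(NCc2cncn2Cc2ccc(C#N)cc2)cc1-c1ccccc1`: in a functional assay on NIH3T3 cells (Mus musculus) (a lower number here means that less compound is needed, a higher number that more compound is needed for the effect), compound 1 gives > 10 uM, which is a limit of the assay and not a number.
Compound 2, `COC(=O)[C@H](CCSC)NC(=O)c1ccc(NCc2cncn2Cc2ccc(Cl)cc2)cc1-c1ccccc1`: in this assay compound 2 gives > 10 uM, likewise a limit.
Compound 3, `CSCC[C@H](NC(=O)c1ccc(NCc2cncn2Cc2ccc(Cl)cc2)cc1-c1ccccc1)C(=O)O`: in this assay compound 3 gives > 10 uM, again a limit.

Compound 2 therefore stands nowhere on a numerical scale; its value is the limit of > 10 uM in this assay, at which 3 of the 3 values shown sit. Within the data shown here, the one measured step, a step that the two limits leave unreadable from compound 2 to compound 3, hydrogen in place of methyl on an oxygen next to a carbonyl group, is left unreadable by the two limits and says nothing about how the series responds to any change.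

Compound 4, `COC(=O)[C@H](CCSC)NC(=O)c1ccc(NCc2cncn2Cc2ccc(-c3ccccc3)cc2)cc1-c1ccccc1`, differs from compound 2 by phenyl in place of chloro on an aromatic carbon. Among the measured compounds shown here, no measured step touches a change of this kind, so the expectation rests on the unmeasured side alone. Since compound 2 sits at > 10 uM, the estimated step that the limit leaves unreadable from compound 2 to compound 4 is most likely to leave compound 4 at the same limit. Compound 4 is thus expected to give about 20 uM in this assay, within a range from 4 uM to 100 uM.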

Compound 4, concentration for half-maximal effect: > 10 uM
Compound 4 gave a limit, no number (the forecaster's own chance of this, stated with the estimate: 70%); the middle value is on the limit's open side.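

In this assay compound 4 gives > 10 uM, a limit and not a number. Compound 2 sits at a limit as well, so no step can be read between compound 2 and compound 4. The compounds shown leave open how any structural change moves the value, since none of them gives a number: the limit of > 10 uM in this assay, at which 4 of the 4 values shown sit.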